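The source may hold more compounds than are shown below. What is called first, only, known or untested is meant among the compounds shown, and "the series" means these compounds.

Compound 3 `CC1=C(C(=O)OCc2cccnc2)C(c2ccc(Br)cc2)C2=C(CCCC2=O)N1` gives the highest number of the three in a physicochemical assay for lipophilicity, measured as octanol-water partition (on this read-out higher numbers stand for higher lipophilicity and lower numbers for lower lipophilicity), at 2.05. Compound 1 `CC1=C(C(=O)OCc2cccnc2)C(c2ccccc2[N+](=O)[O-])C2=C(CCCC2=O)N1` gives 1.51 and compound 2 `CC1=C(C(=O)OCc2cccnc2)C(c2cccc(O)c2)C2=C(CCCC2=O)N1` gives 1.21; the step of a number 0.54 log units higher from compound 1 to compound 3 (beyond the scatter) and the step of a number 0.84 log units higher from compound 2 to compound 3 (beyond the scatter) were both beyond the scatter, while a number 0.30 log units lower from compound 1 to compound 2 (within the scatter). Compound 4 `CC1=C(C(=O)OCc2cccnc2)C(c2cccs2)C2=C(CCCC2=O)N1` differs from compound 3 by thiophen-2-yl in place of 4-bromophenyl on a saturated ring carbon. Going by the values given here, no measured step exchanges a six-membered aromatic ring of carbon only for a five-membered aromatic ring, so the two steps into compound 3 serve only to show how far a change at this saturated ring carbon has moved this assay, and each was modest. A modest downward step is expected. Compound 4 is therefore estimated at 1.5, between 1.1 and 1.9, a step of a number 0.55 log units lower from compound 3 to compound 4 (beyond the scatter).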

Compound 4, partition coefficient: 1.4
For compound 4 the middle estimate is 0.10 log units above the measured one; the range from low to high includes it.
By their numbers in this assay, from the lowest: compounds 2, 4 and 1 (each within the scatter of the next); then compound 3.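

At this saturated ring carbon, a five-membered aromatic ring with 1 hetero atom proves able to replace 4-bromophenyl with a clear change in this assay: a number 0.65 log units lower from compound 3 to compound 4 (beyond the scatter). The other two steps are small, a number 0.19 log units higher from compound 2 to compound 4 (within the scatter) and a number 0.11 log units lower from compound 1 to compound 4 (within the scatter), so thiophen-2-yl, 3-hydroxyphenyl and 2-nitrophenyl cannot be told apart here, and only compound 3 stands apart from the rest. Nothing measured here accounts for these numbers. From the compounds shown here alone, whether an unsubstituted phenyl, a furan-2-yl or a ring carrying an amine would group with compound 3 or with the other three remains open.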